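Adding a nitro group to compound 2

The compounds below may be only part of what the source reports. "The series", "measured", "known", "first", "only" and "open" are said of these compounds alone.

Compound 1 `O=C(N/N=C/c1cccnc1)c1cc2ccc(O)cc2oc1=O`: 18400 nM
Compound 2 `O=C(N/N=C/c1cccnc1)c1cc2ccccc2oc1=O`: 15900 nM
Compound 3 `O=C(N/N=C/c1cccnc1)c1cc2cc([N+](=O)[O-])ccc2oc1=O`: not yet measured

In a functional assay on HepG2 cells (Homo sapiens) for antiproliferative activity, read by fluorescence and resazurin assay, with a stated time of 48 h (a lower number here means a stronger inhibitor, a higher number a weaker inhibitor), compound 2 gives 15900 nM, and compound 1 gives 18400 nM. These two values lie within the scatter of each other, so neither stands apart. Compound 3 differs from compound 2 by nitro in place of hydrogen on an aromatic carbon. Among the compounds with values here, only one measured step bears on this change: a 1.2-fold lower number from compound 1 to compound 2 (0.06 log units; within the scatter). That step also concerns an aromatic carbon, but the group involved is hydroxy, not nitro, so it offers only a weak guide. It stayed within the scatter, and no clear shift in either direction is therefore expected in this assay. The estimated step is a 1.1-fold lower number from compound 2 to compound 3 (0.03 log units; within the scatter). The value expected for compound 3 is 15000 nM, with an estimated range of 5000 nM to 45000 nM. The range is wide, as a single step is thin evidence.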

Compound 3, half-maximal inhibitory concentration: 17000 nM
The estimate for compound 3 lay 1.1-fold (0.05 log units) below the measured number; the measured number falls inside the stated range.
By their numbers in this assay, from the lowest: compounds 2, 3 and 1 (each within the scatter of the next).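

In this assay, the number does not separate the nitro compound from its parent: a 1.1-fold higher number from compound 2 to compound 3 (0.03 log units; within the scatter). Within the data shown here, until now, the only substituent comparison on the shared core involved hydroxy, whereas compound 3 shows that a nitro group, with no hydrogen-bond donors and 2 hydrogen-bond acceptors, also stays within the scatter on an aromatic carbon of this ring. No separate measurement is available to explain this result.

Going by these compounds, whether an amine, a carboxylic acid or a longer alkyl chain on this same aromatic carbon would move the number beyond the scatter remains open. On these data alone, it is also open whether a nitro group on another carbon of this ring, or a change elsewhere in the shared core, would give a clearer difference.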